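Urea substituent change in the aryloxy sulfonylurea series

A few compounds are considered here, and "the series" means these few. Any claim that something is new, unique, unknown or untested is made for them only; others in the source may bear on it.

Working notes. Of the compounds shown here, three have been measured in a functional assay on HEK293 cells for antagonist activity at thromboxane A2 receptor (Homo sapiens), read by fluorescence and calcium flux; on this read-out lower numbers stand for stronger inhibition and higher numbers for weaker inhibition. Compound 1 `Cc1ccccc1Oc1ccc(C#N)cc1S(=O)(=O)NC(=O)NC(C)(C)C` gives 1470 nM; compound 2 `Cc1cccc(Oc2ccc(C#N)cc2S(=O)(=O)NC(=O)NC(C)(C)C)c1` gives 690 nM; compound 3 `CC(C)NC(=O)NS(=O)(=O)c1cc(C#N)ccc1Oc1ccc(F)cc1` gives 9300 nM, the highest number of the three, so compound 3 is the weakest of the set. Compound 4 `CC(C)(C)NC(=O)NS(=O)(=O)c1cc(C#N)ccc1Oc1ccc(F)cc1` is next in line; it differs from compound 3 by methyl in place of hydrogen on a saturated chain carbon bound to an amide-type nitrogen and two saturated chain carbons, that is isopropylcarbamoyl to (tert-butyl)carbamoyl. Among the compounds with values here, the only single-point step measured so far, a 2.1-fold lower number from compound 1 to compound 2 (0.33 log units; beyond the scatter), concerns the methylphenyl ring on the oxygen and leaves the carbamoyl group untouched, so it gives no direct guide to the present change. Compounds 1 and 2 carry the (tert-butyl)carbamoyl group and give lower numbers than compound 3, but they also differ from it in the ring on the oxygen, so the share of the carbamoyl group in that gap cannot be separated out. A modest lowering is therefore expected for compound 4, a 3.1-fold lower number from compound 3 to compound 4 (0.49 log units; beyond the scatter). The estimate for compound 4 is 3000 nM, with a range from 1000 nM to 9000 nM.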

Compound 4, half-maximal inhibitory concentration: 3890 nM
Compound 4: middle estimate off by 1.3-fold (0.11 log units), on the low side; measured number inside the range.
By their numbers in this assay, from the lowest: compound 2; then compound 1; then compound 4; then compound 3.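

In this assay the change from isopropylcarbamoyl to (tert-butyl)carbamoyl gives (a 2.4-fold lower number from compound 3 to compound 4 (0.38 log units; beyond the scatter)) with 4-fluorophenyl held constant, so the carbamoyl group accounts for part of the gap between compound 3 and the two methylphenyl compounds. With (tert-butyl)carbamoyl held constant, the ring on the oxygen can now be read on its own: 4-fluorophenyl in place of 3-methylphenyl gives (a 5.6-fold higher number from compound 2 to compound 4 (0.75 log units; beyond the scatter)), and 4-fluorophenyl in place of 2-methylphenyl gives (a 2.6-fold higher number from compound 1 to compound 4 (0.42 log units; beyond the scatter)). No supporting data bear on the reason for any of these steps.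

The compounds shown leave open whether the carbamoyl step carries over to a compound with a methylphenyl ring on the oxygen. They also leave open how a cyclopropyl group or a longer chain such as n-butyl would read in place of tert-butyl.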